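Amino in Place of Chloro on Two Related Cores

A few compounds are considered here, and "the series" means these few. Any claim that something is new, unique, unknown or untested is made for them only; others in the source may bear on it.

Three compounds were measured in a functional assay on IGROV-1 cells (Homo sapiens) for cytotoxicity, read by sulforhodamine B assay, with a stated time of 48 h; on this read-out higher numbers stand for weaker inhibition of growth and lower numbers for stronger inhibition of growth:

compound 1, `Nc1nc(Cl)c2ncn(Cc3ccc(CCl)cc3)c2n1`: 22900 nM
compound 2, `ClCc1cccc(Cn2cnc3c(Cl)nc(Cl)nc32)c1`: 5120 nM
compound 3, `ClCc1ccc(Cn2cnc3c(Cl)nc(Cl)nc32)cc1`: 30200 nM

Compound 2 gives the lowest number of the three; the numbers of compound 1 and compound 3 stand above it by gaps beyond the usual scatter. Compound 3 and compound 1 share a core and differ by amino in place of chloro on an aromatic carbon; this change made a 1.3-fold lower number from compound 3 to compound 1 (0.12 log units; within the scatter).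

Compound 4, `Nc1nc(Cl)c2ncn(Cc3cccc(CCl)c3)c2n1`, is not yet measured. It relates to compound 2 by amino in place of chloro on an aromatic carbon, the same change as from compound 3 to compound 1, at a place described in identical words. The difference between the core of compound 2 and the core of compound 3 is not broken down here.

Because a 1.3-fold lower number from compound 3 to compound 1 (0.12 log units; within the scatter) was within the scatter, the step from compound 2 to compound 4 is expected to be small as well, about a 1.1-fold lower number from compound 2 to compound 4 (0.06 log units; within the scatter). Compound 4 is therefore estimated at 4500 nM in this assay, expected to lie between 2000 nM and 11000 nM.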

Compound 4, concentration for total growth inhibition: 12900 nM
Beside the measured number, compound 4's estimate is 2.9-fold (0.46 log units) below it; the whole stated range lies below it.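

On the core of compound 2, amino in place of chloro gave a 2.5-fold higher number from compound 2 to compound 4 (0.40 log units; beyond the scatter) in this assay, so the change did not repeat what it had done on the core of compound 3. The two steps differ, which shows that in these two pairs the outcome of the change depends on the core that carries it: the same change on two cores in this assay, a 1.3-fold lower number (0.12 log units; within the scatter) from compound 3 to compound 1 and a 2.5-fold higher number (0.40 log units; beyond the scatter) from compound 2 to compound 4, 3.3-fold (0.52 log units) apart, beyond the scatter of two such steps

This rests on one pair for each core, so it does not show how the change would behave on any further core, and the data do not tell what in the two cores sets the steps apart.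

The compounds shown carry only chloro or amino at this place, so a methoxy group, a hydroxyl group or a methylamino group there remains open. From the compounds shown here alone, all of them also keep the chloromethyl group, so it remains open whether the steps would hold with a hydroxymethyl or an aminomethyl group in its stead.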